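Compound 3 to Compound 4: Exchanging the Aryl Group

The compounds below may be only part of what the source reports. "The series", "measured", "known", "first", "only" and "open" are said of these compounds alone.

Three compounds have been measured in an in vitro ADME assay on microsomes from liver (Rattus norvegicus) for metabolic stability (a lower number here means slower removal, a higher number faster removal of the compound), so far:
- compound 1 `CC(C)NC(=O)[C@H]1CC[C@@H](n2/c(=N/C(=O)c3ccc(C#N)c(F)c3)[nH]c3ccc(CN4CCC(C(C)(C)O)CC4)cc32)CC1` gives 29 mL.min-1.g-1
- compound 2 `CC(C)NC(=O)[C@H]1CC[C@@H](n2/c(=N/C(=O)c3ccccc3)[nH]c3ccc(CN4CCCCC4)cc32)CC1` gives 389 mL.min-1.g-1
- compound 3 `CC(C)NC(=O)[C@H]1CC[C@@H](n2/c(=N/C(=O)c3cc(F)cc(Cl)c3)[nH]c3ccc(CN4CCC(C(C)(C)O)CC4)cc32)CC1` gives 43 mL.min-1.g-1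

The number for compound 3 lies within the scatter of the number for compound 1, while compound 2 stands far higher. The next compound to be measured is compound 4 `CC(C)NC(=O)[C@H]1CC[C@@H](n2/c(=N/C(=O)c3cccc(C#N)c3)[nH]c3ccc(CN4CCC(C(C)(C)O)CC4)cc32)CC1`. It differs from compound 3 in one place (3-cyanophenyl in place of 3-chloro-5-fluorophenyl on a carbonyl carbon), with 3-cyanophenyl in place of 3-chloro-5-fluorophenyl on a carbonyl carbon. Among the measured compounds shown here, one measured step bears on this change, an exchange on that same carbonyl carbon: a 1.5-fold higher number from compound 1 to compound 3 (0.17 log units; within the scatter). For the measured compounds named here, compound 2 differs from the others in more than one place and offers no such step. A change beyond the scatter is therefore not expected in this assay, and no direction can be claimed with confidence. The estimated step is a 1.2-fold lower number from compound 3 to compound 4 (0.08 log units; within the scatter), which stays within the scatter. For compound 4 the estimated value is 36 mL.min-1.g-1, with an expected range from 18 mL.min-1.g-1 to 72 mL.min-1.g-1.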

Compound 4, intrinsic clearance in microsomes: 17 mL.min-1.g-1
The estimate for compound 4 lay 2.1-fold (0.33 log units) above the measured number; measured number below the stated range.
By their numbers in this assay, from the lowest: compounds 4, 1 and 3 (each within the scatter of the next, the first and the last beyond it); then compound 2.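

In this assay, the exchange on this carbonyl carbon now gives a step beyond the scatter (a 2.5-fold lower number from compound 3 to compound 4 (0.40 log units; beyond the scatter)), although a modest one, whereas the earlier exchange at this place had stayed within it. The other step into 3-cyanophenyl (a 1.7-fold lower number from compound 1 to compound 4 (0.23 log units; within the scatter)) stays within the scatter, so the read-out does not separate 3-cyanophenyl from 4-cyano-3-fluorophenyl at this place, and the outcome of the exchange depends on the group that leaves. No measurement at hand offers an explanation for the lower number with 3-cyanophenyl.

The compounds shown leave open how a pyridine ring or a methoxy-bearing phenyl would read on this carbonyl carbon. As far as these compounds go, it also remains open whether the step from 3-chloro-5-fluorophenyl to 3-cyanophenyl would recur with a different amine in place of the shared hydroxyl-bearing piperidine.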